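Fluoro for trifluoromethyl in a small series

A few compounds are considered here, and "the series" means these few. Any claim that something is new, unique, unknown or untested is made for them only; others in the source may bear on it.

Values in a functional assay on U-251 cells (Homo sapiens) for cytotoxicity; a higher number here means a weaker inhibitor of growth, a lower number a stronger inhibitor of growth:
- compound 1 `COc1ccc(C2=C(c3ccc(SC)cc3)CC3CCCN3C2=O)cc1`: 2000 nM
- compound 2 `CSc1ccc(C2=C(c3ccc(OCC4CO4)cc3)C(=O)N3CCCC3C2)cc1`: 80 nM
- compound 3 `CSc1ccc(C2=C(c3ccc(C(F)(F)F)cc3)C(=O)N3CCCC3C2)cc1`: 800 nM

In this assay compound 3 holds the second highest of the three numbers, at 800 nM, with compound 1 above it and compound 2 below it. The next change gives compound 4 `CSc1ccc(C2=C(c3ccc(F)cc3)C(=O)N3CCCC3C2)cc1`, with fluoro in place of trifluoromethyl on an aromatic carbon, para to a large group (fluoro in place of trifluoromethyl on an aromatic carbon). Going by the values given here, no measured step exchanges these two groups. Two modest steps involve the trifluoromethyl group: a 2.5-fold lower number from compound 1 to compound 3 (0.40 log units; beyond the scatter) with trifluoromethyl in place of methoxy, and a 10-fold higher number from compound 2 to compound 3 (1.00 log units; beyond the scatter) with trifluoromethyl in place of (oxiran-2-yl)methoxy. The large step of a 25-fold lower number from compound 1 to compound 2 (1.40 log units; beyond the scatter) came with oxiran-2-yl in place of hydrogen, and compound 4 carries no oxiran-2-yl. A small step at most modest in size is therefore expected in this assay, with no firm direction. The estimated step is a 1.1-fold higher number from compound 3 to compound 4 (0.05 log units; within the scatter). The estimate for compound 4 is 900 nM, with an expected range from 300 nM to 2700 nM.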

Compound 4, concentration for 50% growth inhibition: 90 nM
The estimate for compound 4 lay 10-fold (1.00 log units) above the measured number; measured number below the stated range.
By their numbers in this assay, from the lowest: compounds 2 and 4 (each within the scatter of the next); then compound 3; then compound 1.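

In this assay, fluoro in place of trifluoromethyl on an aromatic carbon, para to a large group, gives an 8.9-fold lower number from compound 3 to compound 4 (0.95 log units; beyond the scatter), so the number at this position shifts beyond the scatter with a swap from four heavy atoms to one. Compound 4 also stands level with the epoxide-bearing compound 2, a 1.1-fold higher number from compound 2 to compound 4 (0.05 log units; within the scatter), and fluoro in place of methoxy gives a 22-fold lower number from compound 1 to compound 4 (1.35 log units; beyond the scatter), so among these four compounds a number of this size does not depend on an oxiran-2-yl group. No measured information available here accounts for the step.

The compounds shown leave open how hydrogen, chloro or a nitrile at this position would compare with fluoro. Also open, on these data alone, is whether an amine or a longer chain ending in an oxiran-2-yl group would give a lower number than compound 2 and compound 4.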